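The source may report more compounds than this note shows. Statements on the series, on what has been measured and on what is new or still open speak of the compounds shown alone.

Measured so far in an ADME assay on cells (Hepatocyte, Mus musculus) for metabolic stability; a higher number here means that the compound lasts longer, a lower number that the compound disappears faster:
- compound 1 `O=C(OC1CCC(CN2CCN(c3cc(=O)c4cc(C(F)(F)F)cc([N+](=O)[O-])c4s3)CC2)CC1)c1ccncc1`: 0.0817 h
- compound 2 `CC(=O)OC1CCC(CN2CCN(c3cc(=O)c4cc(C(F)(F)F)cc([N+](=O)[O-])c4s3)CC2)CC1`: < 0.15 h
- compound 3 `COc1ccc(C(=O)OC2CCC(CN3CCN(c4cc(=O)c5cc(C(F)(F)F)cc([N+](=O)[O-])c5s4)CC3)CC2)cc1`: 0.295 h

Compound 3 gives the higher of the two actual numbers in this assay, at 0.295 h, and compound 1 gives 0.0817 h. Compound 2 gives only a limit of the assay, < 0.15 h.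

Compound 4 `O=C(OC1CCC(CN2CCN(c3cc(=O)c4cc(C(F)(F)F)cc([N+](=O)[O-])c4s3)CC2)CC1)c1cccs1` has thiophen-2-yl in place of 4-methoxyphenyl on a carbonyl carbon. The three measured compounds differ at this same place, so their steps are the relevant guide. The clearest is a 3.6-fold higher number from compound 1 to compound 3 (0.56 log units; beyond the scatter). The step of an at least 1.9-fold higher number from compound 2 to compound 3 (0.29 log units; that floor lies within the scatter) is less informative, and a step that the limit leaves unreadable from compound 1 to compound 2 gives no usable size. For the measured compounds named here, neither other group gives a number above that of compound 3, although only the step involving compound 1 is clearly beyond the scatter. Compound 4 also loses the 4-methoxyphenyl group, so a lower number is expected, with a drop smaller than the gap separating compound 1 from compound 3. The expected change is a 1.8-fold lower number from compound 3 to compound 4 (0.27 log units; within the scatter). A report of only a limit remains possible. For compound 4 the estimate is 0.16 h, with an expected range of 0.07 h to 0.35 h.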

Compound 4, half-life: 0.0867 h
Beside the measured number, compound 4's estimate is 1.8-fold (0.27 log units) above it; low and high end bracket the measured number.
By their numbers in this assay, from the lowest: compounds 1 and 4 (each within the scatter of the next); then compound 3.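

In this assay the change on the carbonyl carbon gives a 3.4-fold lower number from compound 3 to compound 4 (0.53 log units; beyond the scatter), so the low number of compound 1 is not specific to pyridin-4-yl: a second aromatic group at this place also falls clearly under 4-methoxyphenyl. The five-membered and six-membered aromatic rings are not separated here, with a 1.1-fold higher number from compound 1 to compound 4 (0.03 log units; within the scatter), so exchanging pyridin-4-yl for thiophen-2-yl leaves the half-life within the scatter, and among the aromatic groups shown only 4-methoxyphenyl stands apart. The step between compound 2 and compound 4 cannot be read because compound 2 gives only a limit: the limit of < 0.15 h in this assay, at which 1 of the 4 values shown sits.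

The compounds shown do not separate the contribution of the methoxy group from that of the phenyl ring carrying it, a question that a plain phenyl group at this place would address. On these data alone, all four compounds also share the ester link, so whether that link holds the half-lives in this low range stays open, and an amide in its place would test this.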